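The source may hold more compounds than are shown below. What is called first, only, known or untested is meant among the compounds shown, and "the series" means these compounds.

Measured so far:
Compound 1 `C=C[C@@](C)(/C=C/c1ccc(OC)cc1)CCC=C(C)C` gives > 36600 nM
Compound 2 `C=C[C@@](C)(/C=C/c1ccc(OS(=O)(=O)c2ccc(C)cc2)cc1)CCC=C(C)C` gives > 43400 nM
Compound 3 `C=C[C@@](C)(/C=C/c1ccc(O)cc1)CCC1OC1(C)C` gives > 36600 nM

All three compounds were tested in a functional assay on SEM cells (Homo sapiens) for cytotoxicity, with a stated time of 72 h (a higher number here means that more compound is needed for the effect, a lower number that less compound is needed), and none of them gave an actual number. Compound 3 stands at > 36600 nM as a limit of the assay, not as a measured potency. The two other readings are limits as well, so the three compounds cannot be ranked against one another.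

The compound still to be measured is compound 4 `C=C[C@@](C)(/C=C/c1ccc(O)cc1)CCC=O`. It differs from compound 3 in one place, with formyl in place of 3,3-dimethyloxiran-2-yl on a saturated chain carbon, three bonds along the chain from two double-bonded chain carbons. Going by the values given here, no two measured compounds differ in only one place, so the data give no direct guide to the size of this step. With only limits to go on, no change beyond the usual scatter is expected in this assay, and another limit is the likeliest result. The expected step that the limit leaves unreadable from compound 3 to compound 4 is therefore only a rough estimate. For compound 4 the estimated value is 38000 nM, with an expected range from 12000 nM to 50000 nM.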

Compound 4, half-maximal effective concentration: > 36600 nM
Compound 4 gave a limit, no number; the forecaster's own chance of this, stated with the estimate: 75%; the middle value does not contradict the limit.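

Compound 3 and compound 4 both gave only a limit, not a number, in this assay, so the change from 3,3-dimethyloxiran-2-yl to formyl cannot be read as a step. The compounds shown leave open at what concentration any of them would produce the effect, and whether any of these structural changes would shift it.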